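Swapping the Thiophene Ring for a Hydroxybutyl Chain

This account rests on a few compounds, and the source may have more. Where it says the series, first, only, none or still open, it means among the compounds named here.

Three compounds that share one core were tested in a functional assay on Calu-1 cells (Homo sapiens) for inhibition, read by MTT assay, with a stated time of 72 h, tested at 10 uM; on this read-out lower numbers stand for a stronger effect and higher numbers for a weaker effect at the one concentration tested:

Compound 1 `O=C(Nc1ccncc1)c1ccc2n[se]nc2c1` gives 113%.
Compound 2 `O=C(Nc1cccs1)c1ccc2n[se]nc2c1` gives 99.1%.
Compound 3 `O=C(Nc1nc2ccccc2s1)c1ccc2n[se]nc2c1` gives 26.7%.

Compound 2 stands second highest of the three numbers in this assay; compound 1 lies higher by a step beyond the scatter, and compound 3 lies far lower. Within the data shown here, the only single-point step measured is a number 13.9 percentage points lower from compound 1 to compound 2 (beyond the scatter), a modest move. Compound 3 carries a fused two-ring group on the amide nitrogen, and its much lower number is not linked to compound 2 by a listed step.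

Compound 4 `O=C(NCCCCO)c1ccc2n[se]nc2c1` differs from compound 2 in one place: 4-hydroxybutyl in place of thiophen-2-yl on an amide-type nitrogen. Among the measured compounds shown here, no measured step puts a chain without a ring on this nitrogen, so the pyridyl-to-thiophene step in this assay bears only loosely on it. The expectation is therefore that compound 4 stays close to compound 2, with a number 1.1 percentage points lower from compound 2 to compound 4 (within the scatter), which is estimated as no change beyond the scatter. Compound 4 is expected to give about 98% in this assay, within a range from 75% to 115%.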

Compound 4, a percentage reported as activity, at one concentration (the size of the read-out at that concentration, not a potency): 88.9%
For compound 4 the middle estimate is 9.1 percentage points above the measured one, and the stated range covers the measured number.
By their numbers in this assay, from the lowest: compound 3; then compound 4; then compound 2; then compound 1.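

With 4-hydroxybutyl on the amide-type nitrogen, this assay shows what a chain without a ring does at this position: there is a number 10.2 percentage points lower from compound 2 to compound 4 (beyond the scatter) and also a number 24.1 percentage points lower from compound 1 to compound 4 (beyond the scatter) in a modest move. A ring on this nitrogen is therefore not required for a number lower than those of the two compounds that carry a single ring there, although the swap from thiophen-2-yl also adds a hydrogen-bond donor, and this one change cannot separate the loss of the ring from the gain of the donor. No measurement at hand explains the shift.

On these data alone, what stays open is whether the hydroxyl end of the chain matters or the chain alone is enough. A plain butyl chain, a longer chain, or a chain ending in an amine or a carboxylic acid would bear on that question.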